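Shortening the Hydroxyalkyl Chain in a Cholesterol Transporter Series

The source may report more compounds than this note shows. Statements on the series, on what has been measured and on what is new or still open speak of the compounds shown alone.

Compound 1 `CC(C)(C)OC(=O)NCCCCCNC(=O)CN1CN(c2ccccc2)C2(CCN(C(=O)c3ccc(C(C)(C)C)cc3)CC2)C1=O` gives 13700 nM in an assay on HEK293 cells for displacement of a labelled ligand from NPC1-like intracellular cholesterol transporter 1 (Homo sapiens); on this read-out higher numbers stand for weaker inhibition and lower numbers for stronger inhibition. Compound 2 `CC(C)(C)c1ccc(C(=O)N2CCC3(CC2)C(=O)N(CC(=O)NCCO)CN3c2ccccc2)cc1` gives 1000 nM, and the step of a 14-fold lower number from compound 1 to compound 2 (1.14 log units; beyond the scatter). Compound 3 `O=C(CN1CN(c2ccccc2)C2(CCN(C(=O)c3ccc(C4CCCCC4)cc3)CC2)C1=O)NCCO` gives 2000 nM after a 2.0-fold higher number from compound 2 to compound 3 (0.30 log units; within the scatter); it holds the second highest of the three numbers, nearest to compound 2 and furthest from compound 1. Compound 4 `O=C(CN1CN(c2ccccc2)C2(CCN(C(=O)c3ccc(C4CCCCC4)cc3)CC2)C1=O)NCO` differs from compound 3 by hydroxy in place of hydroxymethyl on a saturated chain carbon bound to an amide-type nitrogen. Going by the values given here, only the step from compound 1 to compound 2 touched this chain, and there a much larger group left; the step from compound 2 to compound 3 was within the scatter. The present change is small. For compound 4 a step of a 1.3-fold higher number from compound 3 to compound 4 (0.10 log units; within the scatter) is expected, within the scatter. Compound 4 is estimated at 2500 nM, between 1000 nM and 6500 nM.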

Compound 4, half-maximal inhibitory concentration: 8300 nM
Compound 4: the middle estimate sits 3.3-fold (0.52 log units) below what was measured; the measured number lies above the stated range.
By their numbers in this assay, from the lowest: compounds 2 and 3 (each within the scatter of the next); then compounds 4 and 1 (each within the scatter of the next).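

Removing a single carbon from the chain, with hydroxymethyl giving way to hydroxy, produces a 4.2-fold higher number from compound 3 to compound 4 (0.62 log units; beyond the scatter) and so weakens inhibition. Even this small edit therefore matters at this position, although the hydrogen-bond donor and acceptor counts stay the same. Nothing available explains the loss.

Still open, from the compounds shown here alone, is whether a longer chain than 2-hydroxyethyl would restore or further weaken inhibition, and whether an amine or a carboxylic acid could replace the hydroxy. The same shortening also remains to be read with tert-butyl in place of cyclohexyl.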